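Replacing a Saturated Chain with a Phenyl Ring

This account rests on a few compounds, and the source may have more. Where it says the series, first, only, none or still open, it means among the compounds named here.

Compound 1 (`COc1cc(/C=C/c2ccc(OCCCCCC(=O)NO)cc2)cc(OC)c1`): 4100 nM
Compound 2 (`COc1cc(/C=C/c2ccc(OCCCCCCC(=O)NO)cc2)cc(OC)c1`): 1070 nM

Of the two compounds measured in a functional assay on HCT-116 cells (Homo sapiens) for cytotoxicity, read by MTT assay, with a stated time of 48 h (on this read-out higher numbers stand for weaker inhibition and lower numbers for stronger inhibition), compound 2 has the lower number at 1070 nM and so shows the stronger inhibition. Compound 3 (`COc1cc(/C=C/c2ccc(OCc3cccc(C(=O)NO)c3)cc2)cc(OC)c1`) differs from compound 2 in one place (3-(hydroxycarbamoyl)phenyl in place of 5-(hydroxycarbamoyl)pentyl on a saturated chain carbon bound to an oxygen on an aromatic ring): 3-(hydroxycarbamoyl)phenyl in place of 5-(hydroxycarbamoyl)pentyl on a saturated chain carbon bound to an oxygen on an aromatic ring. Within the data shown here, the one measured step that bears on this is a 3.8-fold lower number from compound 1 to compound 2 (0.58 log units; beyond the scatter) on lengthening the chain. It shows that a modest shift can arise in this part of the molecule. Among the measured compounds shown here, no measured compound carries a ring here, however, so the data give no direction. The estimated change is a 1.1-fold higher number from compound 2 to compound 3 (0.05 log units; within the scatter) with a modest step either way still expected to be possible. For compound 3 the estimate is 1200 nM (expected range 300 nM to 4500 nM).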

Compound 3, half-maximal inhibitory concentration: 13700 nM
Beside the measured number, compound 3's estimate is 11-fold (1.06 log units) below it; measured number above the stated range.
By their numbers in this assay, from the lowest: compound 2; then compound 1; then compound 3.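

In this assay, putting 3-(hydroxycarbamoyl)phenyl in place of 5-(hydroxycarbamoyl)pentyl gives a 13-fold higher number from compound 2 to compound 3 (1.11 log units; beyond the scatter), a large step where lengthening the chain gave only a modest one. This shows that the position tolerates a ring poorly, at least in this form, and gives the direction that the chain data alone could not. The ring also falls short of the shorter chain, with a 3.3-fold higher number from compound 1 to compound 3 (0.52 log units; beyond the scatter), so compound 3 is the weakest of the three here, and nothing measured explains this loss.

Still open, going by these compounds, is whether a longer chain would lower the number further or whether the trend would reverse. Also open, on these data alone, is whether a ring joined through a saturated chain to the hydroxycarbamoyl group would recover the inhibition seen with compound 2.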